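Pyridinylmethyl in Place of Methoxybenzyl on the Ring Nitrogen

The source may report more compounds than this note shows. Statements on the series, on what has been measured and on what is new or still open speak of the compounds shown alone.

Three compounds have been measured in a functional assay on MCF7 cells (Homo sapiens) for cytotoxicity; a higher number here means a weaker inhibitor, a lower number a stronger inhibitor:
compound 1 `COc1ccc(-n2nc(Nc3cc(C)[nH]n3)c3ccccc3c2=O)cc1`, 3600 nM;
compound 2 `COc1ccc(Cn2nc(Nc3cc(C)[nH]n3)c3ccccc3c2=O)cc1`, > 30000 nM, which is a limit of this assay and not a number;
compound 3 `Cc1cc(Nc2nn(CC(C)C)c(=O)c3ccccc23)n[nH]1`, 4200 nM.

Compound 2 thus sits at the limit of > 30000 nM in this assay, at which 1 of the 3 values shown sits. Compound 4 `Cc1cc(Nc2nn(Cc3ccncc3)c(=O)c3ccccc23)n[nH]1` differs from compound 2 by pyridin-4-yl in place of 4-methoxyphenyl on a saturated chain carbon bound to an aromatic nitrogen. Within the data shown here, two measured steps bear on this change. The step of an at least 8.3-fold higher number from compound 1 to compound 2 (0.92 log units; beyond the scatter) and the step of an at least 7.1-fold lower number from compound 2 to compound 3 (0.85 log units; beyond the scatter) show that replacing the 4-methoxyphenyl at this position with isopropyl, or placing 4-methoxyphenyl directly on the aromatic nitrogen, brings the number back to the lower values of compounds 1 and 3. Pyridin-4-yl, however, keeps one six-membered aromatic ring on the saturated chain carbon, so only a partial recovery is expected. The estimated step is an at least 2.0-fold lower number from compound 2 to compound 4 (0.30 log units; that floor lies within the scatter). Compound 4 is estimated at 15000 nM, in the range 4000 nM to 50000 nM.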

Compound 4, half-maximal inhibitory concentration: > 30000 nM
Compound 4: a limit, no number (the forecaster's own chance of this, stated with the estimate: 40%); middle value at least 2.0-fold (0.30 log units) away from the limit.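

Compound 4 also gives a limit of the assay and not a number, the same one as compound 2: the limit of > 30000 nM in this assay, at which 2 of the 4 values shown sit. Pyridin-4-yl in place of isopropyl gives an at least 7.1-fold higher number from compound 3 to compound 4 (0.85 log units; beyond the scatter), and (pyridin-4-yl)methyl on the aromatic nitrogen gives an at least 8.3-fold higher number from compound 1 to compound 4 (0.92 log units; beyond the scatter). The step between compound 2 and compound 4 cannot be read, both values being limits, so among these compounds a six-membered aromatic ring on the saturated chain carbon, with or without a ring nitrogen, goes with the limit.

As far as these compounds go, how a longer chain, or an amine or carboxylic acid on that ring, would read remains open. So does the true potency of compound 2 and compound 4.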